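Sulfonyl sulfur change from compound 3 to compound 4

The compounds below may be only part of what the source reports. "The series", "measured", "known", "first", "only" and "open" are said of these compounds alone.

Measured so far in a toxicity assay on Vero cells (Chlorocebus sabaeus) for cytotoxicity, read by MTT assay (on this read-out lower numbers stand for stronger inhibition and higher numbers for weaker inhibition), for this series
- Compound 1 `COC(=O)NC(=O)c1ccsc1NC(=O)c1ccc(S(=O)(=O)N2CCCC2)cc1` gives 39.5 ug/mL
- Compound 2 `COC(=O)NC(=O)c1ccsc1NC(=O)c1ccc(S(=O)(=O)N2CCC(C)CC2)cc1` gives 9.13 ug/mL
- Compound 3 `COC(=O)NC(=O)c1ccsc1NC(=O)c1ccc(S(=O)(=O)N2CCC(c3ccccc3)CC2)cc1` is recorded as "nd" (no result reported)

Compound 3 has no number in this assay and so offers no starting value for this step. The change to compound 4 `CCCCNS(=O)(=O)c1ccc(C(=O)Nc2sccc2C(=O)NC(=O)OC)cc1` is butylamino in place of 4-phenylpiperidin-1-yl on a sulfonyl sulfur and stays on the sulfonyl sulfur. For the measured compounds named here, the only measured step that bears on it is a 4.3-fold lower number from compound 1 to compound 2 (0.64 log units; beyond the scatter) and it also falls on a sulfonyl sulfur. Without a value for compound 3, no size or direction can be expected for the step itself. The remaining guide is the span of the measured values, with compound 1 at 39.5 ug/mL and compound 2 at 9.13 ug/mL in the same series. For compound 4 the estimated value is 20 ug/mL with a range from 6 ug/mL to 60 ug/mL expected.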

Compound 4, half-maximal inhibitory concentration: 29.5 ug/mL
Compound 4: middle estimate off by 1.5-fold (0.17 log units), on the low side; the measured number falls inside the stated range.
By their numbers in this assay, from the lowest: compound 2; then compounds 4 and 1 (each within the scatter of the next).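

In this assay, butylamino puts a group with no ring on the sulfonyl sulfur, and the reading is a 3.2-fold higher number from compound 2 to compound 4 (0.51 log units; beyond the scatter), whereas a 1.3-fold lower number from compound 1 to compound 4 (0.13 log units; within the scatter), so the two compounds stay level. A ring on the sulfonyl sulfur is therefore not required for a value in this range, and among the three numbers only compound 2 stands apart. The step from compound 3 cannot be read, and no measurement at hand accounts for these differences. Still open, from the compounds shown here alone, is how a longer chain or a carboxylic acid in place of butylamino on the sulfonyl sulfur would read in this assay.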